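The source may hold more compounds than are shown below. What is called first, only, known or untested is meant among the compounds shown, and "the series" means these compounds.

Measured so far:
- compound 1 `Clc1cccc(Cc2nnc(Cn3nnc4ccccc43)o2)c1`: 230000 nM
- compound 2 `Fc1cccc(Cc2nnc(Cn3nnc4ccccc43)o2)c1`: 237000 nM
- compound 3 `COc1cccc(Cc2nnc(Cn3nnc4ccccc43)o2)c1`: 123000 nM

In a functional assay on HeLa cells (Homo sapiens) for antiproliferative activity, read by MTT assay, with a stated time of 24 h (on this read-out lower numbers stand for stronger inhibition and higher numbers for weaker inhibition), compound 1 does not separate from the other two: the data show a 1.0-fold higher number from compound 1 to compound 2 (0.01 log units; within the scatter) and a 1.9-fold lower number from compound 1 to compound 3 (0.27 log units; within the scatter). The remaining pair gives a 1.9-fold lower number from compound 2 to compound 3 (0.28 log units; within the scatter).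

Compound 4 `COc1ccccc1Cc1nnc(Cn2nnc3ccccc32)o1` carries 2-methoxyphenyl in place of 3-chlorophenyl on a saturated chain carbon bound to an aromatic carbon.

The closest guide is a 1.9-fold lower number from compound 1 to compound 3 (0.27 log units; within the scatter), which also swaps chloro for methoxy. Going by the values given here, no measured compound carries 2-methoxyphenyl, so that part remains untested. A small step toward lower numbers, not beyond the scatter, is expected: the estimate is a 1.5-fold lower number from compound 1 to compound 4 (0.19 log units; within the scatter). For compound 4 the expected value is 150000 nM, with an estimated range of 70000 nM to 320000 nM.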

Compound 4, half-maximal inhibitory concentration: 11000 nM
Estimate against measurement, compound 4: 14-fold (1.13 log units) above; the measured number lies below the stated range.
By their numbers in this assay, from the lowest: compound 4; then compounds 3, 1 and 2 (each within the scatter of the next).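

In this assay, the place of the methoxy group on the ring matters far more than the earlier swaps suggested: 2-methoxyphenyl in place of 3-methoxyphenyl gives an 11-fold lower number from compound 3 to compound 4 (1.05 log units; beyond the scatter) while the core stays the same. The comparisons with the other two compounds are also large, with a 21-fold lower number from compound 1 to compound 4 (1.32 log units; beyond the scatter) and a 22-fold lower number from compound 2 to compound 4 (1.33 log units; beyond the scatter) in the same series. Nothing available explains this gain.

On these data alone, whether the gain belongs to methoxy alone remains open. An amine, a hydroxyl or a longer ether chain on the ring could show whether other groups share it.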